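Swapping hydroxyphenyl groups next to the ring nitrogen

The source may report more compounds than this note shows. Statements on the series, on what has been measured and on what is new or still open speak of the compounds shown alone.

Measured compounds: compound 1 `Oc1ccc(-c2cc(-c3ccccc3O)cc(-c3cccc(O)c3)n2)cc1`, 650 nM; compound 2 `Oc1ccc(-c2cc(-c3cccc(O)c3)cc(-c3ccccc3O)n2)cc1`, 50000 nM; compound 3 `Oc1ccc(-c2cc(-c3ccccc3O)cc(-c3ccc(O)cc3)n2)cc1`, 5350 nM.

In a functional assay on T47D cells (Homo sapiens) for cytotoxicity, read by CCK-8 assay, with a stated time of 4 days (a lower number here means a stronger inhibitor, a higher number a weaker inhibitor), compound 1 gives the lowest number of the three, with compound 3 nearest and compound 2 furthest. Compound 4 `Oc1cccc(-c2cc(-c3ccccc3O)cc(-c3ccccc3O)n2)c1` differs from compound 1 by 2-hydroxyphenyl in place of 4-hydroxyphenyl on an aromatic carbon. Within the data shown here, the one measured step at this position is an 8.2-fold higher number from compound 1 to compound 3 (0.92 log units; beyond the scatter), a modest weakening. Compound 2 also carries a 2-hydroxyphenyl group next to the ring nitrogen, and its value is far higher than that of compound 1, though the two are not a single-change pair. Both readings point the same way, so a weakening in this assay is expected, a 12-fold higher number from compound 1 to compound 4 (1.09 log units; beyond the scatter). Compound 4 is estimated at 8000 nM, within 1500 nM to 40000 nM.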

Compound 4, half-maximal inhibitory concentration: 5760 nM
Compound 4: the middle estimate sits 1.4-fold (0.14 log units) above what was measured, and the stated range covers the measured number.
By their numbers in this assay, from the lowest: compound 1; then compounds 3 and 4 (each within the scatter of the next); then compound 2.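

In this assay, among these compounds, the exchange of 4-hydroxyphenyl for 2-hydroxyphenyl gives an 8.9-fold higher number from compound 1 to compound 4 (0.95 log units; beyond the scatter) and is the first measured single change to this group of compound 1. It stands with an 8.2-fold higher number from compound 1 to compound 3 (0.92 log units; beyond the scatter) as a second loss beyond the scatter, so both single changes shown for compound 1 weaken it. Nothing measured here gives a reason for this. The compounds shown leave open how a methoxy group or an amine would read in place of the hydroxyl on this ring. They also leave open what a plain phenyl group would give.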